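Ring-closing the amine side chain: compound 2 to compound 3

A few compounds are considered here, and "the series" means these few. Any claim that something is new, unique, unknown or untested is made for them only; others in the source may bear on it.

Two compounds share one core and differ only in the amine carried on a saturated chain carbon bound to an aromatic carbon. In an assay on cells for displacement of a labelled ligand from corticotropin-releasing factor receptor 1 (Homo sapiens), with a stated time of 100 min (a higher number here means a weaker inhibitor, a lower number a stronger inhibitor), compound 1 `C=CCN(CCC)Cc1c(C(F)(F)F)nc2n(-c3c(C)cc(C)cc3C)c(Cl)cn12` gives 4.5 nM, while compound 2 `Cc1cc(C)c(-n2c(Cl)cn3c(CN(C)Cc4ccccc4)c(C(F)(F)F)nc23)c(C)c1` gives 160 nM, the highest of the two numbers; the step of a 36-fold higher number from compound 1 to compound 2 (1.55 log units; beyond the scatter) shows how strongly this amine governs the read-out. Compound 3 `Cc1cc(C)c(-n2c(Cl)cn3c(CN4CCC(c5ccccc5)C4)c(C(F)(F)F)nc23)c(C)c1` is the next variation: 3-phenylpyrrolidin-1-yl in place of benzyl(methyl)amino on a saturated chain carbon bound to an aromatic carbon. For the measured compounds named here, no measured step covers a ring closure of this kind, so the single step from compound 1 to compound 2 offers only the lesson that changes here can be large, without saying in which direction this one will go. The expected step of a 1.3-fold lower number from compound 2 to compound 3 (0.12 log units; within the scatter) is therefore centred near no change, with wide room either way. Compound 3 is estimated at 120 nM, between 20 nM and 700 nM.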

Compound 3, inhibition constant: 610 nM
The estimate for compound 3 lay 5.1-fold (0.71 log units) below the measured number, and the stated range covers the measured number.
By their numbers in this assay, from the lowest: compound 1; then compound 2; then compound 3.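

In this assay the step of a 3.8-fold higher number from compound 2 to compound 3 (0.58 log units; beyond the scatter) is modest but beyond the scatter, so closing the amine into 3-phenylpyrrolidin-1-yl does not recover the ground lost with benzyl(methyl)amino, and compound 3 is the weakest of the three. The larger step of a 140-fold higher number from compound 1 to compound 3 (2.13 log units; beyond the scatter) adds to the picture: at this saturated chain carbon, both amines carrying a six-membered aromatic ring give higher numbers than allyl(propyl)amino, which has none. Nothing available here explains this difference.

The compounds shown cannot separate the effect of the ring closure from that of the phenyl group, and plain pyrrolidine or piperidine would help to pull the two apart. Also open, as far as these compounds go, is whether another open-chain amine, such as dipropylamine, would match or improve on compound 1.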